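Lengthening the Carbonyl Side Chain of Compound 3

This account rests on a few compounds, and the source may have more. Where it says the series, first, only, none or still open, it means among the compounds named here.

In a functional assay on the whole organism for positive allosteric modulation, with Mus musculus as the target (a lower number here means that less compound is needed, a higher number that more compound is needed for the effect), compound 1 `CCC(=O)N(c1ccc(Cl)c(Cl)c1)C1CCCC1O` gives 0.4 mg/kg, compound 2 `CN(C)C1CCCC1N(C=O)c1ccccc1` gives 40 mg/kg and compound 3 `CC(=O)N(c1ccccc1)C1CCCC1N(C)C` gives 7 mg/kg. Compound 3 therefore holds the middle place of the three: it needs less compound than compound 2 and more than compound 1. Compound 1 differs from compound 3 in more than one place, so its low number cannot be pinned on any single change.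

The next compound is compound 4 `CCCC(=O)N(c1ccccc1)C1CCCC1N(C)C`, and its difference from compound 3 is ethyl in place of hydrogen on a saturated chain carbon bound to a carbonyl carbon. Put simply, acetyl becomes propylcarbonyl, so the chain on the carbonyl grows longer.

Among the measured compounds shown here, the one measured step that bears on this is methyl in place of hydrogen on a carbonyl carbon, a modest change at the same part of the molecule: a 5.7-fold lower number from compound 2 to compound 3 (0.76 log units; beyond the scatter). For the measured compounds named here, a single step cannot show whether a longer chain keeps lowering the number, and no measured compound carries this chain on the same core. A smaller move in the same direction is the cautious expectation, and it may well stay within the scatter. The expected step is a 1.4-fold lower number from compound 3 to compound 4 (0.15 log units; within the scatter). For compound 4 the estimated dose is 5 mg/kg, with an expected range from 1.5 mg/kg to 20 mg/kg.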

Compound 4, dose for half-maximal effect: 6 mg/kg
For compound 4 the middle estimate is 1.2-fold (0.08 log units) below the measured one, within the range that was stated.
By their numbers in this assay, from the lowest: compound 1; then compounds 4 and 3 (each within the scatter of the next); then compound 2.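

In this assay, adding ethyl on the saturated chain carbon bound to the carbonyl carbon gives a 1.2-fold lower number from compound 3 to compound 4 (0.07 log units; within the scatter), so the longer chain cannot be told apart from the shorter one, and the earlier step gave no sign of this. Set against the hydrogen on the carbonyl carbon, propyl gives a 6.7-fold lower number from compound 2 to compound 4 (0.82 log units; beyond the scatter), so among these three compounds, replacing that hydrogen with a chain shifts the number beyond the scatter, whereas going from methyl to propyl does not. No measurement here speaks to what lies behind this result.

From the compounds shown here alone, whether a still longer chain such as butyl or pentyl, a branched isopropyl or a cyclopropyl ring on the carbonyl would also leave the number in place remains open. Going by these compounds, compound 1 differs from compound 3 and compound 4 in more than one place, so it also remains open whether chain length on the carbonyl would matter any more on the core of compound 1.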